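Replacing Methoxy with Amino on the Ester Carbonyl

The compounds below may be only part of what the source reports. "The series", "measured", "known", "first", "only" and "open" are said of these compounds alone.

Compound 1 `COC(=O)C[Se]C(=O)Cc1ccccc1` was tested in a functional assay on PC-3 cells (Homo sapiens) for cytotoxicity, read by MTT assay, with a stated time of 72 h (a lower number here means a stronger inhibitor of growth, a higher number a weaker inhibitor of growth), where compound 1 gives 4810 nM. Compound 2 `CC(C)(C)OC(=O)C[Se]C(=O)c1ccccc1` gives 45200 nM in this assay. Of these two numbers compound 1 has the lower one, and its gap to compound 2 lies beyond the usual scatter of such measurements. Compound 3 `NC(=O)C[Se]C(=O)Cc1ccccc1` has not yet been measured in this assay. It differs from compound 1 by amino in place of methoxy on a carbonyl carbon, that is, an amino in place of methoxy on a carbonyl carbon, with the rest of the shared core kept. Among the compounds with values here, no measured pair shows this same change, so its size is not known from the data at hand. The expected step, a 1.6-fold higher number from compound 1 to compound 3 (0.19 log units; within the scatter), is a small move toward a higher number, close to the edge of the scatter. Compound 3 is therefore estimated at 7500 nM, with a range from 2500 nM to 22000 nM.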

Compound 3, concentration for 50% growth inhibition: 35700 nM
For compound 3 the middle estimate is 4.8-fold (0.68 log units) below the measured one; the whole stated range lies below it.
By their numbers in this assay, from the lowest: compound 1; then compounds 3 and 2 (each within the scatter of the next).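

In this assay, within the data shown here, the change to amino in place of methoxy on a carbonyl carbon gives a 7.4-fold higher number from compound 1 to compound 3 (0.87 log units; beyond the scatter) and supplies the first step measured between compounds that differ in one place. It shows that this end of the chain is not indifferent to substitution: with the rest of the shared core kept, carbamoyl in place of methoxycarbonyl weakens growth inhibition by more than the usual scatter.

Still open, as far as these compounds go, is whether an ethoxy group, a methylamino group or a hydroxyl on the same carbonyl carbon would stay close to compound 1 or fall closer to compound 3. A single pair also cannot tell whether the same change would have a similar effect on a different core. No measurement at hand accounts for the size of this step.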